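This account rests on a few compounds, and the source may have more. Where it says the series, first, only, none or still open, it means among the compounds named here.

Measured compounds:
compound 1 `O=C(Cn1cc(CN2C(=O)C(=O)c3c(Cl)ccc(Cl)c32)nn1)OC1CCCCC1` — in a functional assay on TE-1 cells (Homo sapiens) for inhibition, read by CCK-8 assay, with a stated time of 72 h (on this read-out higher numbers stand for weaker inhibition and lower numbers for stronger inhibition), compound 1 gives 14200 nM
compound 2 `O=C1C(=O)N(Cc2cn(CC(=O)N3CCOCC3)nn2)c2c(Cl)ccc(Cl)c21` — compound 2 gives 119000 nM
compound 3 `O=C1C(=O)N(Cc2cn(CC(=O)N3CCNCC3)nn2)c2c(Cl)ccc(Cl)c21` — compound 3 gives "nd(insoluble)" (no result reported), that is no number; the compound did not dissolve and no result was obtained.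

Among the compounds with values here, compound 3 therefore stands nowhere on the numbers; the only two values in this assay belong to compound 1 and compound 2. Compound 4 `O=C(Cn1cc(CN2C(=O)C(=O)c3c(Cl)ccc(Cl)c32)nn1)Nc1ccccc1` differs from compound 3 as follows: anilino in place of piperazin-1-yl on a carbonyl carbon. Within the data shown here, the single measured step, an 8.4-fold higher number from compound 1 to compound 2 (0.92 log units; beyond the scatter), also exchanges the group on the carbonyl carbon, and it is the only step that bears on the present change, though neither of its ends carries the piperazin-1-yl or the anilino group. With compound 3 giving no number, the expectation for compound 4 in this assay rests on the span shown by compound 1 at 14200 nM and by compound 2 at 119000 nM for variation at this carbonyl. Compound 4 is expected to fall inside that span, estimated at 35000 nM with a range from 8000 nM to 150000 nM.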

Compound 4, half-maximal inhibitory concentration: 30600 nM
Beside the measured number, compound 4's estimate is 1.1-fold (0.06 log units) above it, and the stated range covers the measured number.
By their numbers in this assay, from the lowest: compound 1; then compound 4; then compound 2.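

In this assay anilino adds a third readable group on the carbonyl carbon, with a 3.9-fold lower number from compound 2 to compound 4 (0.59 log units; beyond the scatter) for anilino in place of morpholin-4-yl and a 2.2-fold higher number from compound 1 to compound 4 (0.33 log units; beyond the scatter) for anilino in place of cyclohexyloxy. Both steps lie beyond the scatter, so the order from the lowest number runs cyclohexyloxy, anilino, morpholin-4-yl. Among these compounds, a nitrogen attached to this carbonyl carbon does not by itself set the number as high as that of compound 2, and compound 4 stands between the two earlier values. The data shown give no explanation for this order.

Still open, from the compounds shown here alone, is how cyclohexylamino on the same carbonyl carbon would compare with cyclohexyloxy in compound 1 and anilino in compound 4. Also open, going by these compounds, is whether a benzylamino group would stay within this span.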